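Removing One Methoxy Group: Expected Effect on Cytotoxicity

The source may report more compounds than this note shows. Statements on the series, on what has been measured and on what is new or still open speak of the compounds shown alone.

Three compounds have been measured in a functional assay on COLO 205 cells (Homo sapiens) for cytotoxicity, read by MTT assay, with a stated time of 72 h; a higher number here means a weaker inhibitor, a lower number a stronger inhibitor:
Compound 1 `COc1ccc(C(=O)c2cc(OC)c(OC)c(OC)c2)cc1NC(=O)/C=C/c1cc(OC)c(OC)c(OC)c1` gives 5200 nM
Compound 2 `COc1ccc(C(=O)c2cc(OC)c(OC)c(OC)c2)cc1NC(=O)/C=C/c1ccc(F)c(F)c1` gives 6020 nM
Compound 3 `COc1cc(C(=O)c2cc(OC)c(OC)c(OC)c2)cc(NC(=O)/C=C/c2cc(OC)c(OC)c(OC)c2)c1OC` gives 5300 nM

Compound 3 stands second highest of these three numbers, but all three lie within the usual scatter of one another, so no ranking can be read from them. Compound 4 `COc1ccc(/C=C/C(=O)Nc2cc(C(=O)c3cc(OC)c(OC)c(OC)c3)cc(OC)c2OC)cc1OC` differs from compound 3 by hydrogen in place of methoxy on an aromatic carbon, which in words is hydrogen in place of methoxy on an aromatic carbon, placed ortho to a methoxy group and meta to a large group and to a methoxy group.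

Among the compounds with values here, two measured steps bear on this. The step of a 1.2-fold higher number from compound 1 to compound 2 (0.06 log units; within the scatter) exchanged the whole aryl group on the double-bonded chain and changed nothing beyond the scatter. The step of a 1.0-fold higher number from compound 1 to compound 3 (0.01 log units; within the scatter) added a methoxy group elsewhere and likewise stayed within the scatter. A smaller change on the same aryl group is therefore expected to leave this assay unchanged beyond the scatter, as a 1.0-fold higher number from compound 3 to compound 4 (0.02 log units; within the scatter). Compound 4 is estimated at 5500 nM, with a range from 2500 nM to 12000 nM.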

Compound 4, half-maximal inhibitory concentration: 5700 nM
The estimate for compound 4 lay 1.0-fold (0.02 log units) below the measured number; the measured number falls inside the stated range.
By their numbers in this assay, from the lowest: compounds 1, 3, 4 and 2 (each within the scatter of the next).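

In this assay the change from 3,4,5-trimethoxyphenyl to 3,4-dimethoxyphenyl gives a 1.1-fold higher number from compound 3 to compound 4 (0.03 log units; within the scatter) and so stays within the scatter. Within the data shown here, until now this aryl group had only been exchanged whole, so this is the first view of a single methoxy group leaving it: at this place, ortho to a methoxy group, hydrogen serves as well as methoxy in this assay. No measurement shown gives a reason for this flat result.

From the compounds shown here alone, whether an amine or a carboxylic acid at this place would move the number beyond the scatter remains open. Also open, going by these compounds, is whether the same loss of methoxy would read the same way on the core of compound 1, which carries one methoxy group fewer than the core of compound 3.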